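Aryl swap on the saturated ring carbon: notes

The compounds below may be only part of what the source reports. "The series", "measured", "known", "first", "only" and "open" are said of these compounds alone.

Compound 1 `N#CC1=C(N)N(c2ccc(S(N)(=O)=O)cc2)C2=C(CCCC2)C1c1ccccc1` gives 20% in a functional assay on Ehrlich cells (Mus musculus) for cytotoxicity, read by trypan blue exclusion, with a stated time of 2 h, tested at 50 ug/mL (on this read-out higher numbers stand for a stronger effect at the one concentration tested and lower numbers for a weaker effect), and compound 2 `Cc1ccc(C2C(C#N)=C(N)N(c3ccc(S(N)(=O)=O)cc3)C3=C2CCCC3)cc1` gives 80% in this assay, the highest of the two numbers. Among the measured compounds shown here, the only measured step, a number 60 percentage points higher from compound 1 to compound 2 (beyond the scatter), is the one that bears on compound 3 `N#CC1=C(N)N(c2ccc(S(N)(=O)=O)cc2)C2=C(CCCC2)C1c1ccccc1O`, which differs from compound 2 by 2-hydroxyphenyl in place of 4-methylphenyl on a saturated ring carbon. The methyl whose entry gave that rise is lost, and nothing measured speaks to the entering 2-hydroxyphenyl, so a fall back toward compound 1 is expected in this assay. Compound 3 is therefore estimated at 35% (10% to 70%), with the expected step being a number 45 percentage points lower from compound 2 to compound 3 (beyond the scatter).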

Compound 3, a percentage reported as activity, at one concentration (the size of the read-out at that concentration, not a potency): 50%
The estimate for compound 3 lay 15 percentage points below the measured number; the range from low to high includes it.
By their numbers in this assay, from the lowest: compound 1; then compound 3; then compound 2.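

The aryl group on the saturated ring carbon responds to more than the methyl: a hydroxy group on that aryl ring also raises the read-out in this assay (a number 30 percentage points higher from compound 1 to compound 3 (beyond the scatter)). The gain is smaller than with methyl, since 2-hydroxyphenyl in place of 4-methylphenyl gives a fall (a number 30 percentage points lower from compound 2 to compound 3 (beyond the scatter)). The data offer no explanation for the gap between these two groups.

Still open, as far as these compounds go, is whether the gap follows the substituent or its ring position, which 4-hydroxyphenyl and 2-methylphenyl would separate. From the compounds shown here alone, the effect of an amine or a carboxylic acid on this aryl ring is also open.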